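The source may hold more compounds than are shown below. What is called first, only, known or untested is meant among the compounds shown, and "the series" means these compounds.

Measured so far in an ADME assay on HepG2 cells (Homo sapiens) for cytotoxicity, read by resazurin assay, with a stated time of 24 h; on this read-out lower numbers stand for higher toxicity in this test and higher numbers for lower toxicity in this test:
- compound 1 `O=C(O)c1c(O)cc(Cl)cc1CCc1ccc2ccccc2c1`: 35000 nM
- compound 2 `Cc1cc(O)c(C(=O)O)c(C=Cc2ccc3ccccc3c2)c1`: 30000 nM

Within the data shown here, compound 1 at 35000 nM and compound 2 at 30000 nM lie within the usual scatter of each other, so compound 1 stands level with the only other measured number.

Compound 3 `COc1cc(O)c(C(=O)O)c(CCc2ccc3ccccc3c2)c1` has not yet been measured. It keeps the core of compound 1 but carries methoxy in place of chloro on an aromatic carbon, para to a carboxy group and meta to a hydroxy group: methoxy in place of chloro on an aromatic carbon.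

Among the measured compounds shown here, no measured pair shows a step at a single place, so the data do not directly inform this change. No step beyond the scatter is expected in this assay, and the expectation starts from compound 1 at 35000 nM. The estimated change is a 1.1-fold higher number from compound 1 to compound 3 (0.06 log units; within the scatter). For compound 3 the expected value is 40000 nM, with an estimated range from 18000 nM to 90000 nM.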

Compound 3, half-maximal cytotoxic concentration: 71000 nM
Compound 3: the middle estimate sits 1.8-fold (0.25 log units) below what was measured; low and high end bracket the measured number.
By their numbers in this assay, from the lowest: compounds 2 and 1 (each within the scatter of the next); then compound 3.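

In this assay, among these compounds, the aromatic carbon para to the carboxy group and meta to the hydroxy group gives the first single-place comparison: methoxy in place of chloro gives a 2.0-fold higher number from compound 1 to compound 3 (0.31 log units; beyond the scatter) with the rest of the core held constant. The step is modest but lies beyond the scatter, so the group at this carbon does bear on the read-out, in the direction of lower toxicity in this test. No measurement at hand accounts for this step.

Still open, as far as these compounds go, is whether the step belongs to methoxy specifically or would also appear with another group at this carbon, such as fluoro, an amine or a longer ethoxy chain. Also open, from the compounds shown here alone, is whether the same exchange would give a similar step if the carboxy or hydroxy group of the core were replaced.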